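Hydroxy End Group Replacing Methanesulfonamide on the Chain

The source may hold more compounds than are shown below. What is called first, only, known or untested is meant among the compounds shown, and "the series" means these compounds.

Compound 1, `CC(C)(C)OC(=O)NCCNC(=O)CN1CN(c2ccccc2)C2(CCN(C(=O)c3ccc(C(C)(C)C)cc3)CC2)C1=O`: 10900 nM
Compound 2, `CC(C)(C)OC(=O)NCCCCCNC(=O)CN1CN(c2ccccc2)C2(CCN(C(=O)c3ccc(C(C)(C)C)cc3)CC2)C1=O`: 13700 nM
Compound 3, `CC(C)(C)c1ccc(C(=O)N2CCC3(CC2)C(=O)N(CC(=O)NCCCCNS(C)(=O)=O)CN3c2ccccc2)cc1`: 4500 nM

Three compounds share one core and differ only in the tail carried on the chain that runs from an amide-type nitrogen. In an assay on HEK293 cells for displacement of a labelled ligand from NPC1-like intracellular cholesterol transporter 1 (Homo sapiens) (on this read-out higher numbers stand for weaker inhibition and lower numbers for stronger inhibition), compound 3 gives 4500 nM, the lowest number of the three. Its nearest neighbour is compound 1 with 10900 nM. Compound 2 lies furthest away with 13700 nM.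

Compound 4, `CC(C)(C)c1ccc(C(=O)N2CCC3(CC2)C(=O)N(CC(=O)NCCCCO)CN3c2ccccc2)cc1`, carries one change from compound 3: hydroxy in place of methanesulfonamido on a saturated chain carbon, four bonds along the chain from an amide-type nitrogen. The measured steps that bear on this are a 2.4-fold lower number from compound 1 to compound 3 (0.38 log units; beyond the scatter) and a 3.0-fold lower number from compound 2 to compound 3 (0.48 log units; beyond the scatter), both modest gains when a carbamate tail gives way to methanesulfonamido, while a 1.3-fold higher number from compound 1 to compound 2 (0.10 log units; within the scatter) shows that lengthening the carbamate tail changes little. For the measured compounds named here, no measured step shows what a hydroxy end group does here, so the expectation leans on the finding that tail changes moved the number only modestly. The step of a 1.6-fold higher number from compound 3 to compound 4 (0.19 log units; within the scatter) is expected to be small, at most a modest weakening. Compound 4 is therefore estimated at 7000 nM, within a range from 3000 nM to 16000 nM.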

Compound 4, half-maximal inhibitory concentration: 19200 nM
Beside the measured number, compound 4's estimate is 2.7-fold (0.44 log units) below it, and the stated range ends below it.
By their numbers in this assay, from the lowest: compound 3; then compounds 1, 2 and 4 (each within the scatter of the next).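

In this assay, the hydroxy end group gives up the advantage seen with methanesulfonamido, with a 4.3-fold higher number from compound 3 to compound 4 (0.63 log units; beyond the scatter) on the same chain. It also leaves compound 4 within the scatter of both carbamate compounds, with a 1.4-fold higher number from compound 2 to compound 4 (0.15 log units; within the scatter) and a 1.8-fold higher number from compound 1 to compound 4 (0.25 log units; within the scatter), so among these four compounds only the methanesulfonamido tail stands apart. No measurement shown here explains what sets this tail apart.

Still open, going by these compounds, is which part of methanesulfonamido matters: an amine or an acetamide at the same chain end would help separate the role of the nitrogen from that of the sulfonyl group. Also open, on these data alone, is how chain length affects this tail, which a shorter or longer chain ending in methanesulfonamido would show.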